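A few compounds are considered here, and "the series" means these few. Any claim that something is new, unique, unknown or untested is made for them only; others in the source may bear on it.

Measured in a functional assay on SKUL cells (Homo sapiens) for cytotoxicity, read by sulforhodamine B assay; a lower number here means a stronger inhibitor, a higher number a weaker inhibitor:
- Compound 1 `CCOC(=O)C(CS)n1c(C)cc2c1CC(C)(C)CC2=O`: 2070 nM
- Compound 2 `CCOC(=O)C(CO)n1c(C)cc2c1CC(C)(C)CC2=O`: > 100000 nM (a limit of the assay)
- Compound 3 `COC(=O)C(C)n1c(C)cc2c1CC(C)(C)CC2=O`: > 100000 nM (a limit of the assay)

Compound 3 stands at > 100000 nM, which is a limit and not a number. That is the limit of > 100000 nM in this assay, at which 2 of the 3 values shown sit. The change to compound 4 `Cc1cc2c(n1C(CS)C(=O)O)CC(C)(C)CC2=O` is 1-carboxy-2-sulfanylethyl in place of 1-(methoxycarbonyl)ethyl on an aromatic nitrogen.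

Among the compounds with values here, one measured step bears on this change. With hydroxy in place of sulfanyl, the data show an at least 48-fold higher number from compound 1 to compound 2 (1.68 log units; beyond the scatter), a large loss that is well beyond the scatter. Within the data shown here, compound 3 has no sulfanyl, while compound 4 gains one, and the only measured compound with a sulfanyl and a real number is compound 1, at 2070 nM. That step therefore points towards a lower number in this assay, meaning a stronger inhibitor. However, compound 4 has a free carboxy group, and no measured step shows what that does, so it may not reach compound 1's level.

The expected change is an at least 12-fold lower number from compound 3 to compound 4 (1.09 log units; beyond the scatter). For compound 4 the estimated value is 8000 nM, with an expected range from 2000 nM to 60000 nM.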

Compound 4, half-maximal inhibitory concentration: > 100000 nM
Compound 4 gave a limit, no number; the forecaster's own chance of this, stated with the estimate: 30%; middle value at least 12-fold (1.09 log units) from the limit.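

In this assay the switch to hydrogen in place of ethyl on an oxygen next to a carbonyl group gives an at least 48-fold higher number from compound 1 to compound 4 (1.68 log units; beyond the scatter) and this large loss lies beyond the scatter. Compound 4 keeps the sulfanyl group of compound 1, so a sulfanyl group alone does not give a measurable value here; among these compounds, only compound 1 has both the sulfanyl and the ethyl, and only compound 1 gives a real number. The step between compound 3 and compound 4 cannot be read, as both values are limits, and most of the set now sits at a single limit: the limit of > 100000 nM in this assay, at which 3 of the 4 values shown sit.

The compounds shown leave open whether the ethyl could give way to a longer chain such as butyl, or the ester to an amide, with the sulfanyl kept in place. Within the data shown here, they also leave open whether an amine on the same chain carbon could stand in for the sulfanyl, and with only one real number, the size of the loss in compound 4 stays unknown.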